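Working notes: from compound 2 to compound 3

The source may report more compounds than this note shows. Statements on the series, on what has been measured and on what is new or still open speak of the compounds shown alone.

Measured in a functional assay on PCa 2b cells (Homo sapiens) for cytotoxicity, read by MTT assay, with a stated time of 72 h; on this read-out lower numbers stand for stronger inhibition and higher numbers for weaker inhibition:
- compound 1 `CCOc1ccc(/C=C(\C(=O)/C=C/C2=C(C)CCCC2(C)C)C(=O)/C=C/c2ccc(OCC)c(OCC)c2)cc1OCC`: 6800 nM
- compound 2 `COc1cc(/C=C/C(=O)/C(=C/c2ccc3ccccc3n2)C(=O)/C=C/C2=C(C)CCCC2(C)C)ccc1O`: "not determined" (no result reported)

Compound 2 has no number in this assay, so it stands nowhere on the scale. The change to compound 3 `COc1cc(/C=C(\C(=O)/C=C/C2=C(C)CCCC2(C)C)C(=O)/C=C/c2ccc(O)c(OC)c2)ccc1O` is 4-hydroxy-3-methoxyphenyl in place of quinolin-2-yl on a double-bonded chain carbon bound to a double-bonded chain carbon. With no starting value, no size or direction of step in this assay can be expected. Going by the values given here, the only guide is compound 1 at 6800 nM, which resembles compound 3 in the shared core. For compound 3 the expected value is 4000 nM, with an estimated range of 1000 nM to 15000 nM.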

Compound 3, half-maximal inhibitory concentration: 2500 nM
The estimate for compound 3 lay 1.6-fold (0.20 log units) above the measured number; the range from low to high includes it.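

In this assay no new step can be read from compound 2 to compound 3. The compounds shown leave open how quinolin-2-yl and 4-hydroxy-3-methoxyphenyl compare at this place. No evidence bears on the result.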